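A few compounds are considered here, and "the series" means these few. Any claim that something is new, unique, unknown or untested is made for them only; others in the source may bear on it.

Working notes on the series in a physicochemical assay for solubility; a lower number here means a less soluble compound, a higher number a more soluble compound. Compound 1 `C[C@H](Oc1ccc(S(C)(=O)=O)cc1C(=O)N1Cc2ccccc2C1)C(F)(F)F` gives < 1 ug/mL, which is a limit and not a number. Among the compounds with values here, compound 2 `C[C@H](Oc1ccc(S(C)(=O)=O)cc1C(=O)N1Cc2ccc(C(F)(F)F)cc2C1)C(F)(F)F` gives 1 ug/mL, the only readable number so far. Compound 3 `C[C@H](Oc1ccc(S(C)(=O)=O)cc1C(=O)N1Cc2ccc(N3CCCC3)cc2C1)C(F)(F)F` gives < 1 ug/mL, which is also a limit and not a number. Compound 3 therefore has no readable value, and the only other result of that kind belongs to compound 1.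

Compound 4 `C[C@H](Oc1ccc(S(C)(=O)=O)cc1C(=O)N1Cc2ccc(N3CCN(C)CC3)cc2C1)C(F)(F)F` carries 4-methylpiperazin-1-yl in place of the pyrrolidin-1-yl of compound 3 on an aromatic carbon: 4-methylpiperazin-1-yl in place of pyrrolidin-1-yl on an aromatic carbon. Three measured steps change a group on an aromatic carbon: a number no lower from compound 1 to compound 2 (the limit leaves the size open), a step that the two limits leave unreadable from compound 1 to compound 3 and a number no higher from compound 2 to compound 3 (the limit leaves the size open). None of them has a readable size, and none involves the group that enters here, so no size can be carried over. Compound 1 and compound 3 keep the expectation low because of the limit of < 1 ug/mL in this assay, at which 2 of the 3 values shown sit. With compound 2 at 1 ug/mL, only a small upward move is expected, and the direction is uncertain. The estimated change is an at least 2.0-fold higher number from compound 3 to compound 4 (0.30 log units; that floor lies within the scatter). For compound 4 the estimated value is 2 ug/mL, with an expected range from 0.5 ug/mL to 15 ug/mL.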

Compound 4, solubility: 490 ug/mL
Estimate against measurement, compound 4: 250-fold (2.39 log units) below; measured number above the stated range.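

In this assay, the group on this aromatic carbon can decide the read-out by a large margin: replacing pyrrolidin-1-yl with 4-methylpiperazin-1-yl gives an at least 490-fold higher number from compound 3 to compound 4 (2.69 log units; beyond the scatter). Within the data shown here, no earlier step could show this. None of them had a readable size. The same entering group also stands well clear of the other two groups at this place, with a 490-fold higher number from compound 2 to compound 4 (2.69 log units; beyond the scatter) against trifluoromethyl and an at least 490-fold higher number from compound 1 to compound 4 (2.69 log units; beyond the scatter) against hydrogen, so a ring amine on this carbon is not enough by itself, as the pyrrolidin-1-yl of compound 3 shows. The steps out of compound 1 and compound 3 give only a floor for their size because each starts from a limit and not a number: the limit of < 1 ug/mL in this assay, at which 2 of the 4 values shown sit.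

The compounds shown leave open whether the step belongs to the second ring nitrogen, the methyl on it or the six-membered ring, which morpholin-4-yl or an unsubstituted piperazin-1-yl at this place would separate. They also do not tell why the read-out moves, or whether 4-methylpiperazin-1-yl gives a step of this size elsewhere on the shared core.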